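Bromo to Trifluoromethyl on the Shared Core: Expected Clearance

A few compounds are considered here, and "the series" means these few. Any claim that something is new, unique, unknown or untested is made for them only; others in the source may bear on it.

Compound 1 `O=C(N[C@H]1CCC[C@H](CO)C1)C1CCN(c2nc3cc(Cl)c(Cl)cc3o2)CC1` gives 27.1 mL/min/kg
Compound 2 `O=C(N[C@H]1CCC[C@H](CO)C1)C1CCN(c2nc3cc(Br)ccc3o2)CC1` gives 25.6 mL/min/kg
Compound 3 `O=C(N[C@H]1CCC[C@H](CO)C1)C1CCN(c2nc3cc(Cl)c(C(F)(F)F)cc3o2)CC1` gives 26.5 mL/min/kg

These three values come from an ADME assay on microsomes from liver (Homo sapiens) for metabolic stability; a lower number here means slower removal, a higher number faster removal of the compound. Compound 2 has the lowest of the three numbers, but all three lie within the scatter of one another, so no real order among them can be claimed. Compound 4 `O=C(N[C@H]1CCC[C@H](CO)C1)C1CCN(c2nc3cc(C(F)(F)F)ccc3o2)CC1` differs from compound 2 by trifluoromethyl in place of bromo on an aromatic carbon. Going by the values given here, the only measured step, a 1.0-fold lower number from compound 1 to compound 3 (0.01 log units; within the scatter), covers a related exchange of a halogen for trifluoromethyl on the same ring and stayed within the scatter. Among the compounds with values here, no measured step involves bromo itself. The expectation for compound 4 is therefore a step of a 1.0-fold higher number from compound 2 to compound 4 (0.01 log units; within the scatter), that is, nothing beyond the scatter. Compound 4 is estimated at 26 mL/min/kg, with a range from 16 mL/min/kg to 42 mL/min/kg.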

Compound 4, clearance: 22.2 mL/min/kg
Compound 4: middle estimate off by 1.2-fold (0.07 log units), on the high side; measured number inside the range.
By their numbers in this assay, from the lowest: compounds 4, 2, 3 and 1 (each within the scatter of the next).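

Bromo itself now has a measured exchange: in this assay, trifluoromethyl in place of bromo gives a 1.2-fold lower number from compound 2 to compound 4 (0.06 log units; within the scatter) at this aromatic carbon, meta to a fused ring and para to a fused ring. Here, 4 heavy atoms in place of 1 leave clearance within the scatter, so this exchange gives no sign of a real difference. Nothing available bears on a cause for this result. On these data alone, whether an amine, a carboxylic acid or a longer carbon chain at this position would move clearance beyond the scatter remains open.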